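Adding a Dimethylamino Group to the Weakest Phenyl Analogue

The compounds below may be only part of what the source reports. "The series", "measured", "known", "first", "only" and "open" are said of these compounds alone.

Measured so far in a functional assay for inhibition, tested at 60 ug/mL; on this read-out higher numbers stand for a stronger effect at the one concentration tested and lower numbers for a weaker effect:
- Compound 1 `Cc1cc(O)c(C(C)C)cc1-c1cc(-c2ccccc2)c(C#N)c(=O)[nH]1` gives 34%.
- Compound 2 `Cc1cc(O)c(C(C)C)cc1-c1cc(-c2cccs2)c(C#N)c(=O)[nH]1` gives 54.3%.
- Compound 3 `COc1ccc(-c2cc(-c3cc(C(C)C)c(O)cc3C)[nH]c(=O)c2C#N)c(OC)c1` gives 48.5%.

Compound 1 stands lowest of the three numbers. Its nearest neighbour is compound 3, and the change shows a number 14.5 percentage points higher from compound 1 to compound 3 (beyond the scatter); the step to compound 2 is larger, a number 20.3 percentage points higher from compound 1 to compound 2 (beyond the scatter). Between compound 2 and compound 3 the change is a number 5.8 percentage points lower from compound 2 to compound 3 (within the scatter), so those two cannot be told apart.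

Compound 4 `Cc1cc(O)c(C(C)C)cc1-c1cc(-c2ccc(N(C)C)cc2)c(C#N)c(=O)[nH]1` is not yet measured. It differs from compound 1 in one place: dimethylamino in place of hydrogen on an aromatic carbon. The two measured steps that bear on this both alter the same phenyl on the shared core of compound 1, and both raised the read-out beyond the scatter, though only modestly. Replacing the whole ring by thiophen-2-yl gave the larger gain; decorating it into 2,4-dimethoxyphenyl gave the smaller gain. Adding a dimethylamino group to the ring is closer to the second kind of change, so a modest rise is expected, a number 12 percentage points higher from compound 1 to compound 4 (beyond the scatter), though a result inside the scatter would not surprise. Compound 4 is therefore estimated at 46%, with a range from 30% to 64% in this assay.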

Compound 4, a percentage reported as inhibition, at one concentration (the size of the read-out at that concentration, not a potency): 53%
The estimate for compound 4 lay 7 percentage points below the measured number; measured number inside the range.
By their numbers in this assay, from the lowest: compound 1; then compounds 3, 4 and 2 (each within the scatter of the next).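

In this assay, a single dimethylamino group on the phenyl ring of compound 1, para to a large group, gives a number 19 percentage points higher from compound 1 to compound 4 (beyond the scatter) without any change to the ring itself or a second added group. Set against the other two compounds, the new one shows a number 4.5 percentage points higher from compound 3 to compound 4 (within the scatter) and also a number 1.3 percentage points lower from compound 2 to compound 4 (within the scatter) so 4-(dimethylamino)phenyl, 2,4-dimethoxyphenyl and thiophen-2-yl cannot be told apart in this read-out, although each stands beyond the scatter from plain phenyl. Nothing measured on these compounds accounts for this shared gain.

The compounds shown leave open whether the gain belongs to dimethylamino in particular, or would also come with a primary amine, a single methoxy group or a carboxylic acid on that same carbon. They also leave open what happens with dimethylamino on another carbon of the phenyl ring, and whether longer chains than methyl on the nitrogen would keep the read-out where it now stands.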